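Compound 3 and its unmeasured chain analogue, compound 4

The source may hold more compounds than are shown below. What is called first, only, known or untested is meant among the compounds shown, and "the series" means these compounds.

Measured in an in vitro ADME assay on microsomes from liver (Homo sapiens) for metabolic stability, tested at 5 uM; on this read-out higher numbers stand for a longer-lived compound and lower numbers for a shorter-lived compound:
- Compound 1 `CC(C)CCn1nc(-c2cccs2)c(O)c(C2=NS(=O)(=O)c3cc(N(C)S(C)(=O)=O)ccc3N2)c1=O` gives 0.467 h
- Compound 2 `CC(C)CCn1nc(-c2cccs2)c(O)c(C2=NS(=O)(=O)c3cc(CS(C)(=O)=O)ccc3N2)c1=O` gives 0.467 h
- Compound 3 `COC(C)(C)CCn1nc(-c2cccs2)c(O)c(C2=NS(=O)(=O)c3cc(NS(C)(=O)=O)ccc3N2)c1=O` gives > 1 h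

Compound 3 stands at > 1 h and this is a limit of the assay, not a number. Compound 4 `CS(=O)(=O)Nc1ccc2c(c1)S(=O)(=O)N=C(c1c(O)c(-c3cccs3)nn(CC3(C(F)(F)F)CCC3)c1=O)N2` differs from compound 3 in one place (1-(trifluoromethyl)cyclobutyl in place of 2-methoxy-2-methylpropyl on a saturated chain carbon bound to an aromatic nitrogen) and has yet to be measured. Cut one bond further out, the same difference reads 3-methoxy-3-methylbutyl to (1-(trifluoromethyl)cyclobutyl)methyl.

Among the measured compounds shown here, the one measured step (no change at the digits printed from compound 1 to compound 2 (within the scatter)) lies within the scatter and sits on an aromatic carbon, not on this chain, so it bears on the change only weakly. For the measured compounds named here, no measured step touches the chain alone, which leaves no size to carry over. The expectation therefore starts from compound 3 (> 1 h) and inherits the uncertainty of a limit. In this assay no shift beyond the scatter is expected in either direction, so the estimated step is a step that the limit leaves unreadable from compound 3 to compound 4 and nothing firmer. For compound 4 the estimate is 1.2 h with an expected range from 0.6 h to 2.4 h and a fair chance of getting only a limit.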

Compound 4, half-life: 1 h
Beside the measured number, compound 4's estimate is 1.2-fold (0.08 log units) above it; low and high end bracket the measured number.
By their numbers in this assay, from the lowest: compounds 1 and 2 (each within the scatter of the next); then compound 4.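

In this assay compound 4, which carries 1-(trifluoromethyl)cyclobutyl in place of 2-methoxy-2-methylpropyl on a saturated chain carbon bound to an aromatic nitrogen, gives 1 h as a plain number, so this pair now has one firm reading at that place. Compound 3 stands at > 1 h and this is a limit, not a number. The pair therefore shows only the direction that can be printed, a number no higher from compound 3 to compound 4 (the limit leaves the size open) and its size cannot be read, which means the change cannot be said to shorten or to preserve the half-life, because the comparison rests on a limit: the limit of > 1 h in this assay, at which 1 of the 4 values shown sits.

The compounds shown leave open what a number for the 2-methoxy-2-methylpropyl group would be, and with it how large the change from that group to 1-(trifluoromethyl)cyclobutyl really is. Also open, going by these compounds, is how a plain cyclobutyl without the trifluoromethyl, or a chain ending in a carboxylic acid or a primary amine, would read at this place in this assay on the same core.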